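Fluoro to Bromo with Cytotoxicity Resting at the Limit

The compounds below may be only part of what the source reports. "The series", "measured", "known", "first", "only" and "open" are said of these compounds alone.

Compound 1 `CCN(CC)c1cc2[nH]c(C3CCCCC3)nc2cc1NC(=O)OCC(F)(F)F` gives > 100 ug/mL in an ADME assay on Vero cells (Chlorocebus sabaeus) for cytotoxicity, read by resazurin assay, with a stated time of 3 days (a higher number here means a weaker inhibitor, a lower number a stronger inhibitor), a limit of the assay rather than a number.
Compound 2 `CCCc1ccc(C(=O)Nc2cc3nc(C4CCCCC4)[nH]c3cc2N(CC)CC)cc1` gives "not determined" (no result reported) in this assay.
Compound 3 `CCN(CC)c1cc2[nH]c(C3CCCCC3)nc2cc1NC(=O)c1ccc(F)cc1` gives > 100 ug/mL in this assay, again a limit rather than a number.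

Compound 3 therefore stands on a limit, and of the other entries one is also a limit and one carries no result at all. Going by the values given here, the only step between measured compounds, a step that the two limits leave unreadable from compound 1 to compound 3, joins two limits and cannot be read for size or direction.

Compound 4 `CCN(CC)c1cc2[nH]c(C3CCCCC3)nc2cc1NC(=O)c1ccc(Br)cc1` differs from compound 3 by bromo in place of fluoro on an aromatic carbon. No measured step bears on this change in a readable way; the halogen change from fluoro to bromo has no counterpart among the three compounds shown. What remains is that compound 3 is expected to be matched by compound 4 in this assay because the limit of > 100 ug/mL in this assay, at which 2 of the 3 values shown sit, leaves no room to see a shift.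

Compound 4 is therefore expected to give 100 ug/mL in this assay, with a range from 40 ug/mL to 200 ug/mL. The expected step of a number no higher from compound 3 to compound 4 (the limit leaves the size open) is estimated as none beyond the scatter, and a report of only a limit is the most likely outcome.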

Compound 4, half-maximal inhibitory concentration: > 100 ug/mL
Compound 4 was reported as a limit (the forecaster's own chance of this, stated with the estimate: 85%); the middle value sits exactly at the limit.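

The steps from compound 3 to compound 4 and from compound 1 to compound 4 cannot be read for size or direction in this assay, because all three compounds rest on the same limit: the limit of > 100 ug/mL in this assay, at which 3 of the 4 values shown sit.

The compounds shown leave open what number, if any, lies behind this limit for each compound, and whether bromo in place of fluoro changes the result at all.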